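Hydroxy for ureido on a double-bonded nitrogen

The compounds below may be only part of what the source reports. "The series", "measured", "known", "first", "only" and "open" are said of these compounds alone.

Measured so far:
compound 1 `COc1cc2c(cc1CC1OC1(C)C)C(=O)C[C@@H](c1ccc(O)cc1)O2`: 30900 nM
compound 2 `COc1cc2c(cc1CC=C(C)C)/C(=N/NC(N)=O)C[C@@H](c1ccc(O)cc1)O2`: 19500 nM

In a functional assay on MCF7 cells (Homo sapiens) for inhibition, read by sulforhodamine B assay, with a stated time of 48 h (on this read-out higher numbers stand for weaker inhibition and lower numbers for stronger inhibition), compound 2 gives 19500 nM, within the scatter of compound 1 at 30900 nM. Compound 3 `COc1cc2c(cc1CC=C(C)C)/C(=N/O)C[C@@H](c1ccc(O)cc1)O2` carries hydroxy in place of ureido on a double-bonded nitrogen. Within the data shown here, no measured pair shows this change, so the expectation rests only on compound 2 at 19500 nM. No shift beyond the scatter is expected in this assay, and no direction is favoured. The estimated change is a 1.1-fold lower number from compound 2 to compound 3 (0.06 log units; within the scatter). The estimate for compound 3 is 17000 nM, with an expected range of 7000 nM to 40000 nM.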

Compound 3, half-maximal inhibitory concentration: 23600 nM
Compound 3: middle estimate off by 1.4-fold (0.14 log units), on the low side, within the range that was stated.
By their numbers in this assay, from the lowest: compounds 2, 3 and 1 (each within the scatter of the next).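

In this assay, among these compounds, the step of a 1.2-fold higher number from compound 2 to compound 3 (0.08 log units; within the scatter) gives the only reading at this position: on a double-bonded nitrogen, hydroxy and ureido cannot be told apart, although ureido holds 4 heavy atoms and hydroxy holds 1. Over this pair, the read-out does not depend on which of the two groups is present. No measured evidence bears on why the two groups read alike.

As far as these compounds go, whether a methoxy, an amine or a chain ending in a carboxylic acid on that nitrogen would stand apart from compound 2 and compound 3 remains open.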